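This account rests on a few compounds, and the source may have more. Where it says the series, first, only, none or still open, it means among the compounds named here.

Going by the values given here, compound 1 `CCc1nnc(SCc2ccccc2)n1N1C(=O)c2ccccc2C1=O` stands only at a limit on the numbers so far: in a functional assay on PC-3M cells (Homo sapiens) for cytotoxicity, read by MTT assay, with a stated time of 48 h (on this read-out lower numbers stand for stronger inhibition and higher numbers for weaker inhibition), compound 1 gives > 200000 nM, which is a limit of the assay and not a number. Compound 2 `CCc1nnc(SCC(=O)c2ccccc2)n1N1C(=O)c2ccccc2C1=O` gives in this assay > 200000 nM, also a limit. Compound 3 `CCOC(=O)CSc1nnc(CC)n1N1C(=O)c2ccccc2C1=O` gives in this assay > 200000 nM, again a limit. Hence (the limit of > 200000 nM in this assay, at which 3 of the 3 values shown sit), and the three measured steps cannot be sized: a step that the two limits leave unreadable from compound 1 to compound 2, a step that the two limits leave unreadable from compound 1 to compound 3 and a step that the two limits leave unreadable from compound 2 to compound 3. Among the compounds with values here, the step to compound 4 `COc1cc(-c2nnc(SCc3ccccc3)n2N2C(=O)c3ccccc3C2=O)cc(OC)c1OC` is 3,4,5-trimethoxyphenyl in place of ethyl on an aromatic carbon, a change at a different place from those measured, so none of the measured steps bears on it, and the three limits give no floor for compound 1 from which a size of step could be read. Compound 4 is therefore estimated, with wide uncertainty, at 60000 nM in this assay, between 8000 nM and 250000 nM. This expected step an at least 3.3-fold lower number from compound 1 to compound 4 (0.52 log units; beyond the scatter) is an estimate leaning toward a measurable number rather than a further limit.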

Compound 4, half-maximal inhibitory concentration: > 200000 nM
Compound 4: a limit, no number; the forecaster's own chance of this, stated with the estimate: 45%; middle value at least 3.3-fold (0.52 log units) from the limit.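

In this assay, going by these compounds alone, compound 4 gives > 200000 nM, a limit and not a number; compound 1 also stands only at a limit, so no step between them can be read. The compounds shown leave open whether any change on the shared core would give a measurable number: the limit of > 200000 nM in this assay, at which 4 of the 4 values shown sit.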